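This account rests on a few compounds, and the source may have more. Where it says the series, first, only, none or still open, it means among the compounds named here.

Compound 1, `CCOC(=O)/C(=C/c1ccccc1)CN1C(=O)[C@@H](OC)[C@H]1c1ccc(Cl)cc1`: 11100 nM
Compound 2, `COC(=O)/C(=C/c1ccccc1)CN1C(=O)[C@@H](OC)[C@H]1c1ccc(Cl)cc1`: 15600 nM

In a functional assay on MDA-MB-231 cells (Homo sapiens) for antiproliferative activity, read by MTT assay, with a stated time of 48 h (on this read-out higher numbers stand for weaker inhibition and lower numbers for stronger inhibition), compound 1 gives 11100 nM, and compound 2 gives 15600 nM. Going by the values given here, the two numbers lie within the scatter of each other: the step of a 1.4-fold higher number from compound 1 to compound 2 (0.15 log units; within the scatter) is the only measured step here, and it concerns hydrogen in place of methyl on a saturated chain carbon bound to an oxygen next to a carbonyl group, far from the aromatic ring that carries the chloro substituent.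

Compound 3, `CCOC(=O)/C(=C/c1ccccc1)CN1C(=O)[C@@H](OC)[C@H]1c1ccc(F)cc1`, differs from compound 1 by fluoro in place of chloro on an aromatic carbon. Among the compounds with values here, no measured pair bears directly on this exchange; the one step that is known, a 1.4-fold higher number from compound 1 to compound 2 (0.15 log units; within the scatter), touches a different part of the shared core and stayed within the scatter. There is thus no measured ground for expecting a large movement in either direction, and the estimate for compound 3 is kept close to the number for compound 1, with a wide range to reflect the absence of any step on this position. Compound 3 is therefore expected to give about 13000 nM, within a range from 5000 nM to 35000 nM. The expected step of a 1.2-fold higher number from compound 1 to compound 3 (0.07 log units; within the scatter) is estimated not to exceed the scatter.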

Compound 3, half-maximal inhibitory concentration: 14000 nM
Compound 3: middle estimate off by 1.1-fold (0.03 log units), on the low side, within the range that was stated.
By their numbers in this assay, from the lowest: compounds 1, 3 and 2 (each within the scatter of the next).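

In this assay, putting fluoro in place of chloro on the aromatic carbon para to a large group gives a 1.3-fold higher number from compound 1 to compound 3 (0.10 log units; within the scatter) and so stays within the scatter. This gives the position its first measured step, and it shows that the 4-chlorophenyl to 4-fluorophenyl change, which exchanges one halogen atom for another, does not separate the two compounds on this read-out. The other step available from compound 1, a 1.4-fold higher number from compound 1 to compound 2 (0.15 log units; within the scatter) at the saturated chain carbon bound to an oxygen next to a carbonyl group, also stays within the scatter, so neither of the two places tested has yet produced a step beyond it, and nothing measured on these compounds accounts for the size of the new step.

Going by these compounds, both halogens tested on this ring are single atoms with no hydrogen-bond donors or acceptors, so it remains open whether an amine, a carboxylic acid or a methoxy group at the same place would give a step beyond the scatter. On these data alone, it also remains open whether a longer chain, such as butyl, at the other end of compound 1 would do so.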